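A few compounds are considered here, and "the series" means these few. Any claim that something is new, unique, unknown or untested is made for them only; others in the source may bear on it.

Of the compounds shown here, three have been tested for their ability to slow the growth of a colon cancer cell line, in a functional assay on KM12 cells (Homo sapiens) for cytotoxicity, read by sulforhodamine B assay, with a stated time of 48 h; a higher number here means a weaker inhibitor of growth, a lower number a stronger inhibitor of growth. Compound 1, `ClCc1cccc(Cn2cnc3nc(Cl)nc(Cl)c32)c1`, gives 16600 nM. Compound 2, `ClCc1ccc(Cn2cnc3c(Cl)nc(Cl)nc32)cc1`, gives 1820 nM. Compound 3, `ClCc1ccc(Cn2cnc3ncnc(Cl)c32)cc1`, gives 1650 nM, the lowest of the three numbers, though its gap to compound 2 lies within the usual scatter, so the two cannot be ranked against each other; only compound 1 stands clearly apart, with a number beyond the scatter above that of compound 3.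

The next compound, compound 4, `ClCc1ccc(Cn2cnc3nc(Cl)nc(Cl)c32)cc1`, has not yet been measured. It differs from compound 3 in one place: chloro in place of hydrogen on an aromatic carbon. The change sits on the fused core, not on the benzyl arm, and the three measured compounds already show that the core can vary with little effect, since compound 2 and compound 3 carry different cores yet give numbers within the scatter of each other.

On that basis no step beyond the scatter is expected, and the expected step, a 1.1-fold higher number from compound 3 to compound 4 (0.04 log units; within the scatter), is small in either direction. Compound 4 is therefore expected to give about 1800 nM, with a likely range from 700 nM to 4500 nM.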

Compound 4, concentration for 50% growth inhibition: 260 nM
Compound 4: middle estimate off by 6.9-fold (0.84 log units), on the high side; measured number outside the range, below it.
By their numbers in this assay, from the lowest: compound 4; then compounds 3 and 2 (each within the scatter of the next); then compound 1.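

Placing a chloro group on this aromatic carbon, between two ring nitrogen atoms, is not a silent change: in this assay it gives a 6.3-fold lower number from compound 3 to compound 4 (0.80 log units; beyond the scatter). Going by these compounds alone, until now no single change could be read on its own, so this is the first direct sign that this one position on the core influences growth inhibition, and that the addition of one heavy atom there is enough to move the number beyond the scatter. No supporting measurement accompanies the result, so the data show the size of the step but offer no explanation for it.

The compounds shown carry only hydrogen or chloro at this position, so it remains open whether the step is particular to chloro or would also appear with another group there, such as fluoro, methyl, methoxy or an amine. From the compounds shown here alone, it is also open how much of the activity depends on the chloromethyl group on the benzyl arm, since every compound here carries it and none has a plain methyl or a hydroxymethyl in its place.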